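A few compounds are considered here, and "the series" means these few. Any claim that something is new, unique, unknown or untested is made for them only; others in the source may bear on it.

Measured compounds: compound 1 `O=C(O)[C@H]1NC[C@H](O)[C@@H](O)[C@H]1O` gives 2.6% in an assay on isolated protein for inhibition of cytosolic endo-beta-N-acetylglucosaminidase (Homo sapiens), tested at 1000 uM; a lower number here means less inhibition, a higher number more inhibition at the concentration tested (going by the name of the read-out); compound 2 `O=C(O)[C@@H]1NC[C@@H](O)[C@H](O)[C@@H]1O` gives 0.8%; compound 3 `O=C(O)[C@@H]1NC[C@H](O)[C@@H](O)[C@H]1O` gives 42%.

Compound 2 stands lowest of the three; compound 1 sits nearest, within the scatter, and compound 3 furthest, beyond it. Compound 4 `O=C(O)[C@H]1NC[C@@H](O)[C@@H](O)[C@@H]1O` is the next candidate, and the change is the two compounds have the same atoms and bonds and differ only in configuration as drawn: 2 of 4 stereo elements differ; a stereocentre at a saturated ring carbon is drawn R in compound 2 and S in compound 4; a stereocentre at a saturated ring carbon is drawn S in compound 2 and R in compound 4. All measured steps are configuration changes alone: a number 1.8 percentage points lower from compound 1 to compound 2 (within the scatter) (the fact that compounds 1 and 2 differ only in the configuration as drawn), a number 39.4 percentage points higher from compound 1 to compound 3 (beyond the scatter) (the fact that compounds 1 and 3 differ only in the configuration as drawn) and a number 41.2 percentage points higher from compound 2 to compound 3 (beyond the scatter) (the fact that compounds 2 and 3 differ only in the configuration as drawn). Inverting all centres left the read-out unchanged, while one or three inversions raised it strongly, so configuration can matter greatly without a simple count telling how. Compound 4 is therefore expected to show a moderate rise, a number 11.2 percentage points higher from compound 2 to compound 4 (beyond the scatter), with wide uncertainty, giving an estimated 12% within 0% to 45%.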

Compound 4, a percentage reported as inhibition, at one concentration (the size of the read-out at that concentration, not a potency): 28%
The estimate for compound 4 lay 16 percentage points below the measured number; measured number inside the range.
By their numbers in this assay, from the lowest: compounds 2 and 1 (each within the scatter of the next); then compound 4; then compound 3.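

In this assay, inverting two stereocentres alone gives a number 27.2 percentage points higher from compound 2 to compound 4 (beyond the scatter), and the same count of inversions gives a number 25.4 percentage points higher from compound 1 to compound 4 (beyond the scatter). Compound 3 still stands apart, with a number 14 percentage points lower from compound 3 to compound 4 (beyond the scatter). The read-out among these stereoisomers is therefore graded, with a middle level that the earlier compounds did not show, rather than split into just two levels.

The compounds shown leave open which single stereocentre accounts for these differences. They also leave open whether a methyl ester or a hydroxymethyl group in place of the carboxylic acid would keep this inhibition.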